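Removing an acetyl from a triacetylated trisaccharide fragment

The source may hold more compounds than are shown below. What is called first, only, known or untested is meant among the compounds shown, and "the series" means these compounds.

Measured compounds: compound 1 `CCCCCCCCO[C@@H]1O[C@@H](C)[C@H](OC(=O)CCCCC)[C@@H](O[C@@H]2O[C@@H](C)[C@H](OC(C)=O)[C@@H](O[C@@H]3O[C@@H](C)[C@H](OC(C)=O)[C@@H](OC(C)=O)[C@H]3O)[C@H]2OC(C)=O)[C@H]1O` gives 6 uM; compound 2 `CCCCCCCCO[C@@H]1O[C@@H](C)[C@H](OC(=O)CCCCC)[C@@H](O[C@@H]2O[C@@H](C)[C@H](OC(C)=O)[C@@H](O)[C@H]2OC(C)=O)[C@H]1O` gives > 20 uM, a limit of the assay; compound 3 `CCCCCCCCO[C@@H]1O[C@@H](C)[C@H](OC(=O)CCCCC)[C@@H](O[C@@H]2O[C@@H](C)[C@H](OC(C)=O)[C@@H](OC(C)=O)[C@H]2OC(C)=O)[C@H]1O` gives 14 uM.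

In a functional assay on cells (Homo sapiens) for antiproliferative activity, read by MTT assay, with a stated time of 48 h (on this read-out higher numbers stand for an effect only at larger amounts of compound and lower numbers for an effect already at smaller amounts), compound 3 stands highest of the two numbers shown, with compound 1 the nearest at a lower number. Compound 4 `CCCCCCCCO[C@@H]1O[C@@H](C)[C@H](OC(=O)CCCCC)[C@@H](O[C@@H]2O[C@@H](C)[C@H](O)[C@@H](OC(C)=O)[C@H]2OC(C)=O)[C@H]1O` differs from compound 3 by hydrogen in place of acetyl on an oxygen on a saturated carbon. Among the measured compounds shown here, the only measured step of the same kind runs the other way: an at least 1.4-fold lower number from compound 2 to compound 3 (0.15 log units; that floor lies within the scatter), a step at the floor of the scatter that rests on (the limit of > 20 uM in this assay, at which 1 of the 3 values shown sits). Compound 4 is therefore expected to give a number at or somewhat above that of compound 3, a 1.4-fold higher number from compound 3 to compound 4 (0.15 log units; within the scatter), and the estimate for compound 4 is 20 uM, between 10 uM and 40 uM.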

Compound 4, concentration for half-maximal effect: > 20 uM
Compound 4: a limit, no number (the forecaster's own chance of this, stated with the estimate: 40%); the middle value sits exactly at the limit.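

In this assay, the acetoxy to hydroxy change gives an at least 1.4-fold higher number from compound 3 to compound 4 (0.15 log units; that floor lies within the scatter), so this position yields only a floor for the step, and that floor does not go beyond the scatter. Compound 4 gives > 20 uM, a limit and not a number. Loss of an acetyl from compound 3 at this oxygen therefore ends at the limit, as loss at a different oxygen does in compound 2, and neither loss can be sized: the limit of > 20 uM in this assay, at which 2 of the 4 values shown sit.

From the compounds shown here alone, how far compound 4 lies past the limit stays open. So does the effect of an amine or a methyl ether at this oxygen.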